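Series notes: from compound 3 to compound 4

The source may report more compounds than this note shows. Statements on the series, on what has been measured and on what is new or still open speak of the compounds shown alone.

Of the compounds shown here, three of the shared core carry numbers so far. Compound 1 `CCc1nnc(NC(=O)Cn2c(-c3ccccc3)cc(-c3ccccc3)c2-c2ccco2)s1` in an ADME assay on HEK-293T cells (Homo sapiens) for cytotoxicity, read by MTT assay, with a stated time of 72 h, tested at 50 uM (on this read-out lower numbers stand for less inhibition and higher numbers for more inhibition at the one concentration tested (going by the name of the read-out)), gives 81%. Compound 2 `O=C(Cn1c(-c2ccccc2)cc(-c2ccccc2)c1-c1ccco1)NCc1ccccc1` in this assay gives 72.4%, and compound 3 `O=C(Cn1c(-c2ccccc2)cc(-c2ccccc2)c1-c1ccco1)Nc1ccccn1` in this assay gives 69.4%. Of the three numbers, that of compound 3 is the lowest; the step of a number 11.6 percentage points lower from compound 1 to compound 3 (beyond the scatter) is beyond the scatter, whereas a number 3 percentage points lower from compound 2 to compound 3 (within the scatter) and a number 8.6 percentage points lower from compound 1 to compound 2 (within the scatter) stay within it, so against compound 2 no order holds.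

Compound 4 `O=C(Cn1c(-c2ccccc2)cc(-c2ccccc2)c1-c1ccc(Br)cc1)Nc1ccccn1` differs from compound 3 by 4-bromophenyl in place of furan-2-yl on an aromatic carbon. For the measured compounds named here, this change sits on an aromatic carbon of the five-membered aromatic ring with 1 nitrogen, next to the ring nitrogen, a position none of the measured steps alters; all three measured steps vary the group on the amide-type nitrogen and keep the furan-2-yl in place. Going by the values given here, no measured step therefore bears on this change, and the numbers give no ground to expect a move in this assay beyond the scatter in either direction. The number for compound 4 is expected close to that of compound 3, with a step of a number 1.4 percentage points lower from compound 3 to compound 4 (within the scatter) estimated to stay within the scatter. Compound 4 is estimated at 68%, between 50% and 84%. Among the compounds with values here, the range is wide; the change has no precedent in this set.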

Compound 4, a percentage reported as inhibition, at one concentration (the size of the read-out at that concentration, not a potency): 75%
Compound 4: middle estimate off by 7 percentage points, on the low side; measured number inside the range.
By their numbers in this assay, from the lowest: compounds 3, 2, 4 and 1 (each within the scatter of the next, the first and the last beyond it).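

For the compounds shown here, this is the first measured step at the aromatic carbon next to the ring nitrogen: in this assay, the exchange of furan-2-yl for 4-bromophenyl gives a number 5.6 percentage points higher from compound 3 to compound 4 (within the scatter), so no order holds between the pair. With the pyridin-2-yl group held on the amide-type nitrogen, a five-membered aromatic ring with 1 hetero atom can therefore give way to a larger, six-membered aromatic ring of carbon only, carrying bromine, without a step beyond the scatter; this single pair shows that the furan-2-yl is not needed for a number of this size in this assay. No measurement at hand gives a reason for the size or direction of this step.

The pair changes the ring and adds the bromine in one step, leaving open what each contributes; an unsubstituted phenyl at this position, or a 4-aminophenyl or 4-carboxyphenyl group, would separate these parts. The 4-bromophenyl is shown only with pyridin-2-yl on the amide-type nitrogen, so it remains open whether the exchange would give a similar step with benzyl or 5-ethyl-1,3,4-thiadiazol-2-yl there.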